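Benzylselanyl in place of methylsulfanyl on the shared core

The compounds below may be only part of what the source reports. "The series", "measured", "known", "first", "only" and "open" are said of these compounds alone.

Within the data shown here, compound 2 `CS/C(=N\C(=O)c1cc2ccccc2s1)NC(=O)c1cc2ccccc2s1` gives 34700 nM in a functional assay on K562 cells (Homo sapiens) for cytotoxicity, read by MTT assay, with a stated time of 72 h (on this read-out lower numbers stand for stronger inhibition of growth and higher numbers for weaker inhibition of growth), the higher of the two numbers measured so far. Compound 1 `C[Se]/C(=N\C(=O)c1cc2ccccc2s1)NC(=O)c1cc2ccccc2s1` gives 32400 nM in this assay, and the step of a 1.1-fold higher number from compound 1 to compound 2 (0.03 log units; within the scatter) shows that swapping selenium for sulfur on that carbon made no difference beyond the scatter. Compound 3 `O=C(/N=C(/NC(=O)c1cc2ccccc2s1)[Se]Cc1ccccc1)c1cc2ccccc2s1` differs from compound 2 in one place: a group of 8 heavy atoms (7 carbon, 1 selenium; one six-membered aromatic ring of carbon only) in place of a group of 2 heavy atoms (1 carbon, 1 sulfur; no ring), on a carbon with a double bond to nitrogen. Two things change at once here: selenium returns in place of sulfur, and a benzyl group replaces a methyl group. The first part is covered by the step from compound 1 to compound 2, which was within the scatter; the second part has no measured counterpart among these compounds. Compound 3 is therefore expected to sit close to compound 2, with a step of a 1.4-fold lower number from compound 2 to compound 3 (0.14 log units; within the scatter) that is uncertain in direction, and its estimated value is 25000 nM with a range from 6000 nM to 80000 nM.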

Compound 3, concentration for 50% growth inhibition: 14900 nM
Compound 3: middle estimate off by 1.7-fold (0.22 log units), on the high side, within the range that was stated.
By their numbers in this assay, from the lowest: compound 3; then compounds 1 and 2 (each within the scatter of the next).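

In this assay, phenyl in place of hydrogen on the saturated chain carbon bound to selenium gives a 2.2-fold lower number from compound 1 to compound 3 (0.34 log units; beyond the scatter). This shows that the carbon with a double bond to nitrogen, where exchanging selenium and sulfur alone gave no readable change, does respond when the group attached there is enlarged. The full replacement of methylsulfanyl gives a 2.3-fold lower number from compound 2 to compound 3 (0.37 log units; beyond the scatter), also a modest step, and nothing available here explains why growth inhibition strengthens with this change.

On these data alone, it remains open whether the aromatic ring matters or whether a longer chain, such as propyl on selenium, would do the same. Benzylsulfanyl would show whether selenium still makes no readable difference once the benzyl group is present, and an amine on the benzyl ring would test how far this position tolerates further change.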